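Fluorine for hydroxy on the benzyl arm of compound 1

This account rests on a few compounds, and the source may have more. Where it says the series, first, only, none or still open, it means among the compounds named here.

Measured so far:
compound 1 `CN1CCC[C@@H]1Cn1nc(Cc2ccc(O)cc2)c2ccccc2c1=O` — 398 nM
compound 2 `CN1CCCC1CCn1nc(Cc2ccc(Cl)cc2)c2ccccc2c1=O` — 316 nM
compound 3 `COC(=O)c1ccc(Cc2nn(C[C@H]3CCCN3C)c(=O)c3ccccc23)cc1` — > 1990 nM

In an assay for binding affinity to Alpha-1B adrenergic receptor (Homo sapiens) (on this read-out lower numbers stand for stronger inhibition and higher numbers for weaker inhibition), compound 1 gives 398 nM, the higher of the two numbers shown. Compound 2 gives 316 nM, and its step to compound 1 lies within the scatter, so the two stand level. For compound 3 this assay reports only a limit, > 1990 nM, not a number; that is the line (the limit of > 1990 nM in this assay, at which 1 of the 3 values shown sits).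

Going by the values given here, the one measured step at the same arm is an at least 5.0-fold higher number from compound 1 to compound 3 (0.69 log units; beyond the scatter). Among the compounds with values here, it is the only step that bears on the change now considered: compound 4 `CN1CCC[C@@H]1Cn1nc(Cc2cccc(F)c2)c2ccccc2c1=O` differs from compound 1 by 3-fluorophenyl in place of 4-hydroxyphenyl on a saturated chain carbon bound to an aromatic carbon. Compound 3 shows that replacing the hydroxy with a bulkier group costs at least a modest step. Compound 2, which also carries no hydroxy group, nevertheless gives 316 nM, though it differs from compound 1 in more than one place, so no single step can be read from it.

Within the data shown here, on this evidence compound 4 is expected to show a small loss, a 1.5-fold higher number from compound 1 to compound 4 (0.18 log units; within the scatter), with a wide range because the only close step is an at least 5.0-fold higher number from compound 1 to compound 3 (0.69 log units; beyond the scatter) and it is a limit. The estimate for compound 4 is 600 nM, between 180 nM and 2000 nM.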

Compound 4, inhibition constant: 398 nM
The estimate for compound 4 lay 1.5-fold (0.18 log units) above the measured number; the range from low to high includes it.
By their numbers in this assay, from the lowest: compounds 2, 1 and 4 (each within the scatter of the next). At a limit, above all of these: compound 3.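

In this assay, exchanging 4-hydroxyphenyl for 3-fluorophenyl on the saturated chain carbon gives no change at the digits printed from compound 1 to compound 4 (within the scatter), so the hydroxy group and the hydrogen-bond donor it carries are not needed to reach the level of compound 1. This also narrows the reading of the earlier step, an at least 5.0-fold higher number from compound 1 to compound 3 (0.69 log units; beyond the scatter): compound 4 lacks the hydroxy group as well, so its absence alone does not account for that step, and the methoxycarbonyl group itself comes into question. Compound 3 still stands at a limit and not at a number, so the full size of that step stays unknown: the limit of > 1990 nM in this assay, at which 1 of the 4 values shown sits.

The change to compound 4 replaces the substituent and moves it on the ring in a single step, so the compounds shown cannot separate the two, and 4-fluorophenyl and 3-hydroxyphenyl would be needed to do so. They also leave open how this arm responds to other groups, such as a carboxylic acid, an amine or a nitrile, and whether the methoxycarbonyl result extends to a smaller carbonyl group such as acetyl.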